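Swapping 1,3-thiazol-4-yl for methyl on a carbonyl carbon

The source may report more compounds than this note shows. Statements on the series, on what has been measured and on what is new or still open speak of the compounds shown alone.

In an ADME assay on microsomes (Rattus norvegicus) for metabolic stability (on this read-out lower numbers stand for a shorter-lived compound and higher numbers for a longer-lived compound), compound 3 `O=C(c1cscn1)N1CCC(C(=O)N2N=CC[C@H]2c2ccccc2)CC1` gives 0.65 h as its half-life. That number is the higher of the two exact numbers available, the other being compound 2 `O=C(C1CCCC1)N1N=CCC1c1ccccc1` with 0.2 h as its half-life. Compound 1 `O=C(c1cnco1)N1CCC(C(=O)N2N=CC[C@H]2c2ccccc2)CC1` shows > 3 h in the same test, which is a limit of the assay and not a number.

Compound 4 `CC(=O)N1CCC(C(=O)N2N=CC[C@H]2c2ccccc2)CC1` differs from compound 3 in one place: methyl in place of 1,3-thiazol-4-yl on a carbonyl carbon describes the change, which puts methyl in place of 1,3-thiazol-4-yl on a carbonyl carbon. Among the compounds with values here, one measured step bears on this place: an at least 4.6-fold lower number from compound 1 to compound 3 (0.66 log units; beyond the scatter) shows that the group here can move the half-life beyond the scatter. Going by these compounds, its true size stays open, given the limit of > 3 h in this assay, at which 1 of the 3 values shown sits, as its starting point. Within the data shown here, no measured compound carries methyl here, so any forecast is loose. Compound 3 lies at the lower end of that step, so losing its group is expected to raise the number modestly in this assay rather than lower it. The estimated size is a 1.8-fold higher number from compound 3 to compound 4 (0.27 log units; within the scatter) as a rough expectation. For compound 4 the estimated half-life is 1.2 h with an expected range from 0.4 h to 3 h in this test.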

Compound 4, half-life: > 2.75 h
Compound 4 ended at the assay's limit (the forecaster's own chance of this, stated with the estimate: 15%); at least 2.2-fold (0.36 log units) between middle value and limit.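

Within the data shown here, until now, the only measured step at this place ran between two ring groups. Putting methyl in place of 1,3-thiazol-4-yl on the carbonyl carbon gives an at least 4.2-fold higher number from compound 3 to compound 4 (0.62 log units; beyond the scatter) in this assay, so a ring on this carbonyl is not needed for a long half-life, and compound 3 stands out as the short-lived member of the series. The true size of this step stays open because compound 4 sits at a limit: the limit of > 2.75 h in this assay, at which 1 of the 4 values shown sits. Compound 1 also sits at a limit, so the step from it to compound 4 cannot be read: the limit of > 3 h in this assay, at which 1 of the 4 values shown sits.

The compounds shown leave open whether a longer chain such as ethyl or propyl, or an amine on this carbonyl carbon, would keep the half-life as long as methyl does. They also leave open how far past its limit compound 4 really lies.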